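The source may hold more compounds than are shown below. What is called first, only, known or untested is meant among the compounds shown, and "the series" means these compounds.

Compound 3 `CCOc1ccc(-n2nncc2CN2C(=O)C3(C(C#N)=C(N)Oc4c(N)cc5nc6ccccc6nc5c43)c3ccccc32)cc1` was tested in an ADME assay on L02 cells (Homo sapiens) for antiproliferative activity, read by MTT assay, with a stated time of 48 h; on this read-out lower numbers stand for stronger inhibition and higher numbers for weaker inhibition. In this assay compound 3 gives > 50000 nM, which is a limit of the assay and not a number. The two compounds measured alongside it end the same way. Compound 1 `N#CC1=C(N)Oc2c(c3nc4ccccc4nc3c3ccccc23)C12C(=O)N(Cc1cnnn1-c1ccccc1Br)c1ccccc12` gives > 50000 nM, again a limit. Compound 2 `Cc1ccc(Cl)cc1-n1nncc1CN1C(=O)C2(C(C#N)=C(N)Oc3c2c2nc4ccccc4nc2c2ccccc32)c2ccccc21` gives > 50000 nM, also a limit. Within the data shown here, because every value shown sits at the limit of > 50000 nM in this assay, at which 3 of the 3 values shown sit, the one step between compounds that differ in a single group, a step that the two limits leave unreadable from compound 1 to compound 2, cannot be read in size, so nothing measured here shows how a change on the aromatic nitrogen moves the read-out.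

Compound 4 `N#CC1=C(N)Oc2c(N)cc3nc4ccccc4nc3c2C12C(=O)N(Cc1cnnn1-c1ccc(F)c(Cl)c1)c1ccccc12` differs from compound 3 by 3-chloro-4-fluorophenyl in place of 4-ethoxyphenyl on an aromatic nitrogen. Among the measured compounds shown here, no measured step bears directly on this exchange, and the only step available is unreadable. With compound 3 sitting at a limit, the expectation for compound 4 is that it too will reach the limit rather than a number. Compound 4 is therefore expected to give about 50000 nM, with a range from 20000 nM to 100000 nM. The estimated step of a number no higher from compound 3 to compound 4 (the limit leaves the size open) is expected to stay within the scatter.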

Compound 4, half-maximal inhibitory concentration: > 50000 nM
Compound 4 gave a limit, no number; the forecaster's own chance of this, stated with the estimate: 80%; the middle value sits exactly at the limit.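

Compound 4, like compound 3, ends at a limit of the assay and not at a number, so the step between them cannot be read in size, because all values sit at one limit: the limit of > 50000 nM in this assay, at which 4 of the 4 values shown sit. The compounds shown leave open how any change on the aromatic nitrogen moves the read-out.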